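The source may report more compounds than this note shows. Statements on the series, on what has been measured and on what is new or still open speak of the compounds shown alone.

Measured in a functional assay on MCF7 cells (Homo sapiens) for antiproliferative activity, read by MTT assay, with a stated time of 48 h; on this read-out lower numbers stand for stronger inhibition and higher numbers for weaker inhibition:

- Compound 1 `COc1ccc(C2=N/C(=C\c3cc(Br)cc(Br)c3OC(C)=O)C(=O)NN2c2ncc(-c3ccc(Br)cc3)s2)cc1OC`: 3280 nM
- Compound 2 `CC(=O)Oc1c(Br)cc(Br)cc1/C=C1\N=C(c2ccccc2)n2c(=S)nc(C)n2C1=O`: > 100000 nM

Compound 2 has no numerical reading, only a limit of this assay, > 100000 nM. Compound 3 `COc1cc(C2=N/C(=C\c3cc(Br)cc(Br)c3OC(C)=O)C(=O)n3c(C)nc(=S)n32)cc(OC)c1OC` keeps the core of compound 2 and carries 3,4,5-trimethoxyphenyl in place of phenyl on a carbon with a double bond to nitrogen. Among the compounds with values here, no measured step shows this change. Compound 1 gives 3280 nM, so a move towards stronger inhibition is expected, though its size is uncertain. The expected change is an at least 3.3-fold lower number from compound 2 to compound 3 (0.52 log units; beyond the scatter). For compound 3 the estimated value is 30000 nM, with an expected range of 6000 nM to 100000 nM.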

Compound 3, half-maximal inhibitory concentration: 3070 nM
Compound 3: middle estimate off by 9.8-fold (0.99 log units), on the high side; the measured number lies below the stated range.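

In this assay, within the data shown here, 3,4,5-trimethoxyphenyl in place of phenyl on a carbon with a double bond to nitrogen gives an at least 32-fold lower number from compound 2 to compound 3 (1.51 log units; beyond the scatter), the first sign that the group at this place on the core of compound 2 bears on the read-out. Compound 2 gives only a limit, so this step is a minimum and its true size stays unknown: the limit of > 100000 nM in this assay, at which 1 of the 3 values shown sits.

The compounds shown leave open whether the full set of three methoxy groups is needed or a single methoxy group would do. They also do not show how a hydroxy group or a fluorine on the phenyl would fare at this place.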